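A few compounds are considered here, and "the series" means these few. Any claim that something is new, unique, unknown or untested is made for them only; others in the source may bear on it.

Compound 1 (`COc1ccc(/C=C2\CN(C(=S)SCc3cn(Cc4ccccc4F)nn3)C/C(=C\c3ccc(OC)cc3)C2=O)cc1`) has no exact number. In a functional assay on MDA-MB-231 cells (Homo sapiens) for cytotoxicity, read by MTT assay, with a stated time of 24 h (a higher number here means a weaker inhibitor, a lower number a stronger inhibitor), compound 1 gives > 100000 nM as its reading, and that reading is a limit of the assay. Compound 1 therefore stands only at the limit of > 100000 nM in this assay, at which 1 of the 3 values shown sits, and not at any exact point on the scale.

The other two tested compounds returned numbers. Compound 2 (`COc1ccc(/C=C2\CN(Cc3cn(Cc4cccc(Cl)c4)nn3)C/C(=C\c3ccc(OC)cc3)C2=O)cc1`) gives 98000 nM in this assay as its result. Compound 3 (`Cc1ccc(/C=C2\CN(C(=S)SCc3cn(Cc4ccc(F)cc4)nn3)C/C(=C\c3ccc(C)cc3)C2=O)cc1`) gives 45600 nM in this assay as its result.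

Compound 4 (`COc1ccc(/C=C2\CN(C(=S)SCc3cn(Cc4cccc(Cl)c4)nn3)C/C(=C\c3ccc(OC)cc3)C2=O)cc1`) has not yet been measured. It departs from compound 1 in one place, with 3-chlorophenyl in place of 2-fluorophenyl on a saturated chain carbon bound to an aromatic nitrogen. For the measured compounds named here, no measured pair isolates this swap, so the size of the step in this assay cannot be read directly. A modest move toward a lower number is expected, though it may not exceed the scatter. That expectation rests on compound 2 at 98000 nM and compound 3 at 45600 nM as the only numerical results available. The estimated change is an at least 1.4-fold lower number from compound 1 to compound 4 (0.15 log units; that floor lies within the scatter) and remains uncertain. For compound 4 the estimated value is 70000 nM with an expected range from 30000 nM to 140000 nM in this test.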

Compound 4, half-maximal inhibitory concentration: 32000 nM
The estimate for compound 4 lay 2.2-fold (0.34 log units) above the measured number; the range from low to high includes it.
By their numbers in this assay, from the lowest: compounds 4 and 3 (each within the scatter of the next); then compound 2. At a limit, above all of these: compound 1.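

In this assay, for the compounds shown here, 3-chlorophenyl in place of 2-fluorophenyl on a saturated chain carbon bound to an aromatic nitrogen gives an at least 3.1-fold lower number from compound 1 to compound 4 (0.49 log units; beyond the scatter), the first change at this place that can be read on its own, and it lies beyond the scatter. The size of this step is only a floor, because compound 1 stands at a limit and not at an exact number: the limit of > 100000 nM in this assay, at which 1 of the 4 values shown sits. Compound 2 gives 98000 nM in this assay and compound 4 gives 32000 nM with the same 3-chlorophenyl group, so this group does not settle the reading by itself.

The compounds shown do not separate the exchange of fluorine for chlorine from the shift of the substituent on the phenyl ring, a question that 2-chlorophenyl or 3-fluorophenyl at this place would address. They also leave open how an unsubstituted phenyl, a 3-aminophenyl or a 3-carboxyphenyl group would read here.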